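The source may report more compounds than this note shows. Statements on the series, on what has been measured and on what is new or still open speak of the compounds shown alone.

Measured so far:
Compound 1 `O=c1[nH]cc(S(=O)(=O)Nc2ccccc2-c2cn(-c3ccc(F)cc3)nn2)c(=O)[nH]1`: > 20000 nM
Compound 2 `Cc1ccccc1-n1cc(-c2cccc(NS(=O)(=O)c3c[nH]c(=O)[nH]c3=O)c2)nn1`: 6230 nM

Going by the values given here, in a functional assay on OVCAR-3 cells (Homo sapiens) for antiproliferative activity, read by MTT assay, with a stated time of 24 h (on this read-out lower numbers stand for stronger inhibition and higher numbers for weaker inhibition), compound 2 gives 6230 nM, the only actual number available so far. For compound 1, > 20000 nM is a limit and not a number.

Compound 3 `O=c1[nH]cc(S(=O)(=O)Nc2cccc(-c3cn(-c4cccc(Cl)c4)nn3)c2)c(=O)[nH]1` keeps the core of compound 2 and differs in one group: 3-chlorophenyl in place of 2-methylphenyl on an aromatic nitrogen. Among the compounds with values here, no measured pair shows a swap of this kind, so no change beyond the usual scatter is expected. The estimated step is a 1.2-fold lower number from compound 2 to compound 3 (0.10 log units; within the scatter). Compound 3 is expected at 5000 nM, with an estimated range of 1800 nM to 18000 nM.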

Compound 3, half-maximal inhibitory concentration: 3410 nM
Estimate against measurement, compound 3: 1.5-fold (0.17 log units) above; the measured number falls inside the stated range.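

On an aromatic nitrogen of the five-membered ring, putting 3-chlorophenyl in place of 2-methylphenyl gives, in this assay, a 1.8-fold lower number from compound 2 to compound 3 (0.26 log units; within the scatter). This pair therefore shows that these two aromatic groups, with the same count of heavy atoms, cannot be told apart at this position. Nothing measured here gives a reason for the size of this step.

The compounds shown leave open whether a phenyl ring carrying an amine or a carboxylic acid would shift the number beyond the scatter. They also leave open what a simple alkyl chain in place of the aromatic group would do.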